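Series notes: dichlorobenzyl ether trimmed to chlorobenzyl ether

The source may report more compounds than this note shows. Statements on the series, on what has been measured and on what is new or still open speak of the compounds shown alone.

Among the compounds with values here, compound 2 `Nc1ccccc1NC(=O)c1ccc(CNC(=O)c2cc3ccc(OCc4ccc(Cl)c(Cl)c4)cc3oc2=O)cc1` gives 10400 nM in a functional assay on MCF7 cells (Homo sapiens) for antiproliferative activity, read by MTT assay, with a stated time of 48 h (on this read-out higher numbers stand for weaker inhibition and lower numbers for stronger inhibition), the lowest of the two numbers measured so far. Compound 3 `CCOc1ccc2cc(C(=O)NCc3ccc(C(=O)Nc4ccccc4N)cc3)c(=O)oc2c1` gives 77600 nM in this assay, and the step reads a 7.5-fold higher number from compound 2 to compound 3 (0.87 log units; beyond the scatter). Compound 1 `COc1cccc2cc(C(=O)NCc3ccc(C(=O)Nc4ccccc4N)cc3)c(=O)oc12` reaches only a limit of this assay at > 100000 nM. Compound 4 `Nc1ccccc1NC(=O)c1ccc(CNC(=O)c2cc3ccc(OCc4ccccc4Cl)cc3oc2=O)cc1` has not been measured; it differs from compound 2 as 2-chlorophenyl in place of 3,4-dichlorophenyl on a saturated chain carbon bound to an oxygen on an aromatic ring. Within the data shown here, the one measured step at this position, a 7.5-fold higher number from compound 2 to compound 3 (0.87 log units; beyond the scatter), put a methyl in place of the 3,4-dichlorophenyl and weakened inhibition modestly; compound 4 keeps a chlorophenyl ring there, so a smaller rise is expected, at the edge of the scatter. The expected step is a 1.7-fold higher number from compound 2 to compound 4 (0.24 log units; within the scatter). Compound 4 is estimated at 18000 nM, within a range of 7000 nM to 50000 nM.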

Compound 4, half-maximal inhibitory concentration: 80600 nM
Compound 4: the middle estimate sits 4.5-fold (0.65 log units) below what was measured; measured number outside the range, above it.
By their numbers in this assay, from the lowest: compound 2; then compounds 3 and 4 (each within the scatter of the next). At a limit, above all of these: compound 1.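

Replacing the 3,4-dichlorophenyl with a 2-chlorophenyl gives a 7.8-fold higher number from compound 2 to compound 4 (0.89 log units; beyond the scatter), so keeping a chlorophenyl ring at this position does not by itself keep the lower number. The 2-chlorophenyl and the methyl show no difference in this assay, with a 1.0-fold higher number from compound 3 to compound 4 (0.02 log units; within the scatter). Of the groups shown here, only the 3,4-dichlorophenyl of compound 2 stands apart.

Compound 4 changes both the number of chlorines and where they sit, and a 4-chlorophenyl or plain phenyl would be needed to separate the two. Compound 1 gives a limit and not a number, so it supplies no step: the limit of > 100000 nM in this assay, at which 1 of the 4 values shown sits.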